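A few compounds are considered here, and "the series" means these few. Any claim that something is new, unique, unknown or untested is made for them only; others in the source may bear on it.

Of the compounds shown here, two built on one shared core have been measured in an assay for binding affinity to leukotriene B4 receptor 1 (Homo sapiens); on this read-out lower numbers stand for stronger inhibition and higher numbers for weaker inhibition. Compound 1 `COc1ccc(CCCCCCCCOc2ccc(C[S+]([O-])c3cccc(CS(=O)(=O)C(F)(F)F)c3)nc2/C=C/C(=O)O)cc1` gives 225 nM. Among the compounds with values here, compound 2 `COc1ccc(CCCCCCCCOc2ccc(C[S+]([O-])c3cccc(N)c3)nc2/C=C/C(=O)O)cc1` gives 4.7 nM, and the single step between them, a 48-fold lower number from compound 1 to compound 2 (1.68 log units; beyond the scatter), is the only measured step in this set. On these numbers compound 2 stands lowest of the two. Compound 3 `Nc1cccc([S+]([O-])Cc2ccc(OCCCCCCCCc3ccc(F)cc3)c(/C=C/C(=O)O)n2)c1` differs from compound 2 in one place: fluoro in place of methoxy on an aromatic carbon. Within the data shown here, no measured step bears on this change; the one step available concerns a different group on a different ring, and the 4-methoxyphenyl group itself has not been varied among the measured compounds. Among the measured compounds shown here, with no comparable step to lean on, the expectation is a change in this assay no larger than the usual scatter, in either direction. For compound 3 the expected value in this assay is therefore 7 nM, within 2.5 nM to 20 nM, which is an expected step of a 1.5-fold higher number from compound 2 to compound 3 (0.17 log units; within the scatter).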

Compound 3, inhibition constant: 12 nM
Compound 3: the middle estimate sits 1.7-fold (0.23 log units) below what was measured; the measured number falls inside the stated range.
By their numbers in this assay, from the lowest: compound 2; then compound 3; then compound 1.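

Until now the 4-methoxyphenyl group had stayed the same, in compound 1 and compound 2, so nothing showed whether this position matters in this assay. Fluoro in place of methoxy gives a 2.6-fold higher number from compound 2 to compound 3 (0.41 log units; beyond the scatter), so the position does respond to a change of group, although this step is far smaller than the one at the other site, a 48-fold lower number from compound 1 to compound 2 (1.68 log units; beyond the scatter). Nothing available here explains why the number moves with this change.

The compounds shown do not tell whether the higher number comes from losing methoxy or from gaining fluoro, a question that a plain hydrogen, a chloro or a hydroxy group at this position could help to settle. From the compounds shown here alone, it also remains open whether the same change would give a similar step with ((trifluoromethyl)sulfonyl)methyl in place of the amino group.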